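This account rests on a few compounds, and the source may have more. Where it says the series, first, only, none or still open, it means among the compounds named here.

Of the compounds shown here, three have been measured for growth inhibition of a glioblastoma cell line. Compound 1 `C/C(=N/O)c1ccc(NC(=O)Cn2nc(-c3ccccc3)nc2N)cc1` gives 3.56% in a functional assay on SNB-19 cells (Homo sapiens) for inhibition, read by sulforhodamine B assay, with a stated time of 48 h, tested at 10 uM; a lower number here means less inhibition of growth, a higher number more inhibition of growth at the concentration tested. Compound 2 `c1ccc(-c2nc3sc(-c4ccccc4)cn3n2)cc1` gives 11% in this assay, and compound 3 `COc1cc(-c2nc3sc(-c4ccccc4)cn3n2)cc(OC)c1OC` gives 10%. Compound 2 thus carries the highest of the three numbers, but its gap to compound 3 and its gap to compound 1 both lie within the usual scatter, so the three values cannot be ordered with confidence and all sit in the region of weak inhibition.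

Compound 4 `Clc1ccc(-c2cn3nc(-c4ccccc4)nc3s2)cc1` has not yet been tested. It differs from compound 2 in a single place: chloro in place of hydrogen on an aromatic carbon. The new atom sits on an aromatic carbon of a six-membered aromatic ring of carbon only, para to a large group. Among the measured compounds shown here, because compound 2 gives only 11%, and no measured pair in this set shows a step beyond the scatter, the step from compound 2 to compound 4 is expected to be small, a number 3 percentage points higher from compound 2 to compound 4 (within the scatter), in either direction or none beyond the scatter. Compound 4 is therefore estimated at 14%, within a range from 2% to 30%.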

Compound 4, percent growth inhibition at one concentration: 57%
Compound 4: the middle estimate sits 43 percentage points below what was measured, and the stated range ends below it.
By their numbers in this assay, from the lowest: compounds 1, 3 and 2 (each within the scatter of the next); then compound 4.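

In this assay, among the compounds shown here, the change of phenyl to 4-chlorophenyl gives a number 46 percentage points higher from compound 2 to compound 4 (beyond the scatter) and is the first step in this set that stands clear of the scatter. It shows that this position, on a six-membered aromatic ring of carbon only and para to a large group, is not indifferent: a single chlorine atom in place of hydrogen is enough to take compound 2 out of the region of weak inhibition. Nothing given here accounts for the size of this step.

For the compounds shown here, only one group at one place has been seen, and it remains open whether a fluoro, a methoxy, an amine or a carboxylic acid on the same carbon would give a similar step. Also open, going by these compounds, is whether chloro would do the same on the other phenyl group of compound 2.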